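The source may hold more compounds than are shown below. What is called first, only, known or untested is meant among the compounds shown, and "the series" means these compounds.

Measured so far in an ADME assay on the whole organism with Oryza sativa as the target, tested at 0.1 uM; on this read-out lower numbers stand for a stronger effect and higher numbers for a weaker effect at the one concentration tested:

compound 1, `Cc1cccc(NC(=O)N[C@@H](C)c2ccccc2)c1`: compound 1 gives 99%
compound 2, `Cc1ccc(NC(=O)N[C@H](C)c2ccccc2)cc1`: compound 2 gives 100%
compound 3, `CCc1cccc(NC(=O)N[C@@H](C)c2ccccc2)c1`: compound 3 gives 100%

Compound 1 and compound 3 share a core and differ in one place, (methyl in place of hydrogen on a saturated chain carbon bound to an aromatic carbon). The step that this change made is a number 1 percentage points higher from compound 1 to compound 3 (within the scatter). Compound 2 has the same atoms as compound 1, joined differently; the difference between the two cores is not broken down here. Compound 2 is level with compound 3 at the digits shown, and the two together hold the highest numbers of the three, while compound 1 sits within the scatter of both. All three numbers lie close to the top of the scale, so at the one concentration tested none of the three shows much of an effect in this assay.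

Compound 4, `CCc1ccc(NC(=O)N[C@H](C)c2ccccc2)cc1`, is not yet measured. Within the data shown here, it differs from compound 2 by methyl in place of hydrogen on a saturated chain carbon bound to an aromatic carbon, which is the same change as the one from compound 1 to compound 3, at the same place. Among the compounds shown this change occurs twice in all, once measured and once open. The step in this assay is expected to be no change at the digits printed from compound 2 to compound 4 (within the scatter), because the earlier occurrence of the change moved the read-out a number 1 percentage points higher from compound 1 to compound 3 (within the scatter), and because compound 2 already gives 100%, leaving little room for the number to go higher. Compound 4 is therefore estimated at 100%, with a range from 90% to 105%. This rests on a single earlier step, so the expectation is held loosely.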

Compound 4, a percentage reported as activity, at one concentration (the size of the read-out at that concentration, not a potency): 95%
The estimate for compound 4 lay 5 percentage points above the measured number; the range from low to high includes it.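

In this assay, methyl in place of hydrogen on a saturated chain carbon bound to an aromatic carbon, which turns methyl into ethyl, gives a number 5 percentage points lower from compound 2 to compound 4 (within the scatter), and the two occurrences of this change do not differ beyond what repeated measurements would scatter: the same change on two cores in this assay, a number 1 percentage points higher (within the scatter) from compound 1 to compound 3 and a number 5 percentage points lower (within the scatter) from compound 2 to compound 4, 6 percentage points apart, within the scatter of two such steps. Among these compounds, on these two pairs, then, the change carries from the core of compound 1 to the core of compound 2 with no step on either core that stands clear of the scatter, and the opposite signs of the two steps carry no meaning. This does not show that the change is without effect across the series in general, since both pairs lie close to the top of the scale at the one concentration tested, and two pairs with so little effect say nothing about how the same change would behave on a compound with a clear effect in this assay.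

As far as these compounds go, it remains open whether a longer chain, an amine or a carboxylic acid in place of the ethyl would move the read-out beyond the scatter. From the compounds shown here alone, it also remains open whether any compound of this series gives a number well away from the top of the scale.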